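Bromo for nitro on a coumarin amide: a repeated change

A few compounds are considered here, and "the series" means these few. Any claim that something is new, unique, unknown or untested is made for them only; others in the source may bear on it.

Measured compounds:
- compound 1 `CCOc1ccc2nc(Cl)c(/C=N/NC(=O)c3cc4cc([N+](=O)[O-])ccc4oc3=O)cc2c1`: 18100 nM
- compound 2 `CCOc1ccc2nc(Cl)c(/C=N/NC(=O)c3cc4cc(Br)ccc4oc3=O)cc2c1`: 29000 nM
- compound 3 `Cc1noc(NS(=O)(=O)c2ccc(NC(=O)c3cc4cc([N+](=O)[O-])ccc4oc3=O)cc2)c1C`: 15000 nM

In a functional assay on HepG2 cells (Homo sapiens) for antiproliferative activity, read by fluorescence and resazurin assay, with a stated time of 48 h (on this read-out higher numbers stand for weaker inhibition and lower numbers for stronger inhibition), compound 1 gives 18100 nM, and compound 2, which carries the change (bromo in place of nitro on an aromatic carbon), gives 29000 nM; the step of a 1.6-fold higher number from compound 1 to compound 2 (0.20 log units; within the scatter) is within the scatter. Compound 3 gives 15000 nM, and its value lies within the scatter of both compound 1 and compound 2. The difference between the core of compound 3 and the core of compound 1 is not broken down here. Compound 4 `Cc1noc(NS(=O)(=O)c2ccc(NC(=O)c3cc4cc(Br)ccc4oc3=O)cc2)c1C` differs from compound 3 by bromo in place of nitro on an aromatic carbon, the same change as from compound 1 to compound 2. Because the step of a 1.6-fold higher number from compound 1 to compound 2 (0.20 log units; within the scatter) was small, a step of similar size, a 1.6-fold higher number from compound 3 to compound 4 (0.20 log units; within the scatter), is expected from compound 3 to compound 4. Compound 4 is therefore estimated at 24000 nM, roughly between 9000 nM and 60000 nM.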

Compound 4, half-maximal inhibitory concentration: 8800 nM
Estimate against measurement, compound 4: 2.7-fold (0.44 log units) above, outside the stated range (below it).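

In this assay, the new step, a 1.7-fold lower number from compound 3 to compound 4 (0.23 log units; within the scatter), is small on its own, as is the earlier step on the other core, yet the two run in opposite directions and do not match: the same change on two cores in this assay, a 1.6-fold higher number (0.20 log units; within the scatter) from compound 1 to compound 2 and a 1.7-fold lower number (0.23 log units; within the scatter) from compound 3 to compound 4, 2.7-fold (0.44 log units) apart, beyond the scatter of two such steps. The change of bromo in place of nitro therefore did not carry over unchanged from one core to the other. This does not show why the two cores part ways, and two pairs give no rule for the rest of the series.

The compounds shown leave open how other groups at this place on the ring, such as an amine or a carboxylic acid, would behave. They also leave open which of the two steps, if either, a third core would follow.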